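Fluorophenyl Replaces a Methyl Ester on the Shared Core

The source may hold more compounds than are shown below. What is called first, only, known or untested is meant among the compounds shown, and "the series" means these compounds.

Measured so far:
Compound 1 `Cc1ccc(-c2ccc(NC3=CC(=O)c4ncncc4C3=O)cc2F)cc1`: 5000 nM
Compound 2 `COC(=O)c1ccc(NC2=CC(=O)c3ncncc3C2=O)cc1`: 5800 nM

In a functional assay on BXPC-3 cells (Homo sapiens) for cytotoxicity, read by MTT assay, with a stated time of 72 h (a lower number here means a stronger inhibitor, a higher number a weaker inhibitor), compound 2 gives 5800 nM, and compound 1 gives 5000 nM, the two numbers sitting within the scatter of each other, so neither stands apart. Compound 3 `O=C1C(Nc2ccc(-c3ccc(F)cc3)cc2)=CC(=O)c2ncncc21` differs from compound 2 in one place: 4-fluorophenyl in place of methoxycarbonyl on an aromatic carbon. Compound 1 already carries a second aromatic ring of carbon only and gives a value within the scatter of compound 2, so no step beyond the scatter is expected for this change. Compound 3 is expected to give 5000 nM, between 2000 nM and 13000 nM. The expected step of a 1.2-fold lower number from compound 2 to compound 3 (0.06 log units; within the scatter) is estimated to stay within the scatter.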

Compound 3, half-maximal inhibitory concentration: 4400 nM
The estimate for compound 3 lay 1.1-fold (0.06 log units) above the measured number; the measured number falls inside the stated range.
By their numbers in this assay, from the lowest: compounds 3, 1 and 2 (each within the scatter of the next).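

In this assay the change from methoxycarbonyl to 4-fluorophenyl gives only a small step (a 1.3-fold lower number from compound 2 to compound 3 (0.12 log units; within the scatter)). This position on the aromatic ring can therefore carry either an ester or a second aromatic ring of carbon only, with the numbers staying within the scatter. The group that leaves has hydrogen-bond acceptors and the group that enters has none, yet no step beyond the scatter appears, and no measurement on hand offers an explanation. On these data alone, whether an amine or a carboxylic acid at this position would give a larger step remains open.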